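This account rests on a few compounds, and the source may have more. Where it says the series, first, only, none or still open, it means among the compounds named here.

Working notes on the series. Compound 2 `FC(F)(F)c1ccc(COc2cccc(Nc3ncnc4cc5c(cc34)OCCOCCOCCO5)c2)cc1` is the reference point. In a functional assay on DU-145 cells (Homo sapiens) for antiproliferative activity, read by MTT assay, with a stated time of 72 h (on this read-out higher numbers stand for weaker inhibition and lower numbers for stronger inhibition), compound 2 gives 2760 nM. Compound 1 `c1ccc(COc2ccccc2Nc2ncnc3cc4c(cc23)OCCOCCOCCOCCO4)cc1` differs from compound 2 in more than one place; in this assay compound 1 reaches only a limit, > 100000 nM. Compound 3 `FC(F)(F)c1ccc(COc2cccc(Nc3ncnc4cc5c(cc34)OCCOCCO5)c2)cc1` differs from compound 2 in the size of the fused chain on the shared core; in this assay compound 3 likewise reaches only a limit, > 100000 nM. For the measured compounds named here, of the three values shown, compound 2 therefore holds the only actual number, the two others being limits, as summarised by the limit of > 100000 nM in this assay, at which 2 of the 3 values shown sit. Going by the values given here, no pair of measured compounds differs in a single place, so no measured step is available to calibrate the next change.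

Among the compounds with values here, compound 4 `O=[N+]([O-])c1ccc(COc2cccc(Nc3ncnc4cc5c(cc34)OCCOCCOCCO5)c2)cc1` keeps everything of compound 2 and alters only one group: nitro in place of trifluoromethyl on an aromatic carbon. Within the data shown here, with no comparable measured step in hand, the expected step is a 1.1-fold higher number from compound 2 to compound 4 (0.04 log units; within the scatter), that is, nothing beyond the usual scatter in either direction. On that basis compound 4 is estimated at 3000 nM, with a range from 1000 nM to 10000 nM, and a real chance that this assay again returns only a limit for it.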

Compound 4, half-maximal inhibitory concentration: > 100000 nM
Compound 4 ended at the assay's limit; the forecaster's own chance of this, stated with the estimate: 15%; middle value at least 33-fold (1.52 log units) from the limit.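

The 4-(trifluoromethyl)benzyl group of compound 2 proves not to be freely exchangeable: in this assay, the change to 4-nitrobenzyl gives an at least 36-fold higher number from compound 2 to compound 4 (1.55 log units; beyond the scatter). As the only single-place step shown, this is the first direct sign that the measured activity of compound 2 depends on the group on this aromatic carbon, para to a large group, and not on the shared core and fused chain alone; the step has only a lower bound, since the value of compound 4 is a limit. Compound 2 remains the only compound with an actual number: the limit of > 100000 nM in this assay, at which 3 of the 4 values shown sit.

With a single replacement at this position, the compounds shown cannot separate a specific need for trifluoromethyl from a specific penalty for nitro; a nitrile, a chlorine or a methoxy group on the same aromatic carbon would help to tell these apart. On these data alone, the full size of the step also stays open, as does whether the 4-nitrobenzyl group would behave the same way on a longer fused chain.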